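The source may report more compounds than this note shows. Statements on the series, on what has been measured and on what is new or still open speak of the compounds shown alone.

Among the compounds with values here, in an ADME assay on microsomes from liver (Mus musculus) for pharmacokinetics (on this read-out lower numbers stand for slow clearance and higher numbers for fast clearance), compound 2 `Cc1ccc(S(=O)(=O)N[C@@H](CC(=O)NC(C)(C)C)C(=O)NCCNC(=O)c2ccc(F)cc2)cc1` gives 49 mL.min-1.g-1, the lower of the two numbers measured so far. Within the data shown here, the only other measured compound, compound 1 `COc1cccc(C(=O)NCCNC(=O)[C@H](CC(=O)NC(C)(C)C)NS(=O)(=O)c2ccc(C)cc2)c1`, gives 142 mL.min-1.g-1. Compound 3 `C#Cc1cccc(C(=O)NCCNC(=O)[C@H](CC(=O)NC(C)(C)C)NS(=O)(=O)c2ccc(C)cc2)c1` has not yet been measured, and it differs from compound 2 in one place: 3-ethynylphenyl in place of 4-fluorophenyl on a carbonyl carbon. In words, 3-ethynylphenyl stands in place of 4-fluorophenyl on a carbonyl carbon.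

Among the measured compounds shown here, only one measured step bears on this change, and it is a modest one, beyond the scatter, with 4-fluorophenyl in place of 3-methoxyphenyl on a carbonyl carbon. Compound 3 also lacks 4-fluorophenyl, so a 2.9-fold lower number from compound 1 to compound 2 (0.46 log units; beyond the scatter), read backwards, suggests a higher number in this assay. However, 3-ethynylphenyl is not 3-methoxyphenyl, and a single step is thin evidence, so the expected rise is smaller than that step and may not clear the scatter. The expected change is a 1.9-fold higher number from compound 2 to compound 3 (0.29 log units; within the scatter). For compound 3 the estimated value is 95 mL.min-1.g-1, with an expected range from 40 mL.min-1.g-1 to 200 mL.min-1.g-1.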

Compound 3, intrinsic clearance in microsomes: 97 mL.min-1.g-1
For compound 3 the middle estimate is 1.0-fold (0.01 log units) below the measured one; the range from low to high includes it.
By their numbers in this assay, from the lowest: compounds 2, 3 and 1 (each within the scatter of the next, the first and the last beyond it).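

In this assay, the step to compound 3 gives a 2.0-fold higher number from compound 2 to compound 3 (0.30 log units; within the scatter), so the 3-ethynylphenyl group on this carbonyl carbon cannot be told apart from the 4-fluorophenyl group, although the earlier pair, compound 1 and compound 2, lay beyond the scatter of each other. The swap of ethynyl in place of methoxy on an aromatic carbon, which leaves the rest of compound 1 unchanged, gives a 1.5-fold lower number from compound 1 to compound 3 (0.17 log units; within the scatter), so these two substituents cannot be told apart either, and compound 3 sits within the scatter of both neighbours. Nothing in hand gives a reason for any of these numbers.

With compound 3 this close to both neighbours, the three compounds do not settle whether the gap between compound 1 and compound 2 belongs to the fluorine, to the methoxy, or to the place each occupies on the ring. They also leave open how the clearance would respond to a different kind of group on the aromatic carbon, such as an amine or a carboxylic acid in place of the ethynyl.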